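Swapping the Side Group on an Oxazolidinone Scaffold

The source may report more compounds than this note shows. Statements on the series, on what has been measured and on what is new or still open speak of the compounds shown alone.

Measured compounds, with their values in a physicochemical assay for lipophilicity, read by HPLC, measured as octanol-water partition; a higher number here means a more lipophilic compound, a lower number a more polar compound:
- compound 1 `CN1CCN(C[C@H]2CN(c3ccc(-n4cc(-c5ccccn5)cn4)c(F)c3)C(=O)O2)CC1`: 2.2
- compound 2 `CC(=O)OC[C@H]1CN(c2ccc(-n3cc(-c4ccccn4)cn3)c(F)c2)C(=O)O1`: 2.09
- compound 3 `O=C1O[C@@H](CSc2cccs2)CN1c1ccc(-n2cc(-c3ccccn3)cn2)c(F)c1`: 4.29

Compound 3 stands highest of the three in this assay. Its distance to compound 1 and to compound 2 is large: a number 2.09 log units higher from compound 1 to compound 3 (beyond the scatter) and a number 2.20 log units higher from compound 2 to compound 3 (beyond the scatter), both beyond the scatter. Between compound 1 and compound 2 the values lie within the scatter: a number 0.11 log units lower from compound 1 to compound 2 (within the scatter).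

Compound 4 `O=C1O[C@@H](Cn2ccnn2)CN1c1ccc(-n2cc(-c3ccccn3)cn2)c(F)c1` differs from compound 3 in one place: 1H-1,2,3-triazol-1-yl in place of (thiophen-2-yl)sulfanyl on a saturated chain carbon bound to a saturated ring carbon.

Within the data shown here, the steps that bear on this are the two that put a thienylsulfanyl group onto that chain carbon; both moved this assay by a large amount upward. Compound 4 removes that same group again, so a large step downward is expected, toward the region where compound 1 and compound 2 sit. The expected step is a number 1.99 log units lower from compound 3 to compound 4 (beyond the scatter).

For compound 4 the estimate in this assay is 2.3, with a range from 1.7 to 2.9.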

Compound 4, partition coefficient: 2
Compound 4: the middle estimate sits 0.30 log units above what was measured; the range from low to high includes it.
By their numbers in this assay, from the lowest: compounds 4, 2 and 1 (each within the scatter of the next); then compound 3.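

In this assay the change to 1H-1,2,3-triazol-1-yl gives a number 2.29 log units lower from compound 3 to compound 4 (beyond the scatter) and so shows that a five-membered aromatic ring on this saturated chain carbon does not by itself go with the high number of compound 3. The same position also gives a number 0.09 log units lower from compound 2 to compound 4 (within the scatter) and a number 0.20 log units lower from compound 1 to compound 4 (within the scatter) and so places the triazole with the acetoxy and 4-methylpiperazin-1-yl groups. Among these four compounds, three quite different groups therefore sit together, and compound 3 is the one that goes against them.

Still open, going by these compounds, is whether the high number of compound 3 follows its sulfur link or its thiophene ring, which a phenylsulfanyl group or a thiophen-2-yl group joined directly to the chain carbon could separate, and where a carboxylic acid would fall. Nothing available here explains why these groups give these values.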